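Aryl amide exchange on the carbonyl: compound 2 to compound 3

The source may report more compounds than this note shows. Statements on the series, on what has been measured and on what is new or still open speak of the compounds shown alone.

The series keeps one shared core and varies the aryl group on the amide carbonyl. Compound 1 `Cc1ccc(C(=O)Nc2cc(-c3ccccc3)nn2-c2ccccc2)cc1` carries a 4-methylphenyl there, and in an assay on HEK293 cells for displacement of a labelled ligand from metabotropic glutamate receptor 5 (Rattus norvegicus) (on this read-out higher numbers stand for weaker inhibition and lower numbers for stronger inhibition), compound 1 gives 780 nM. Compound 2 `NC(=O)c1ccc(C(=O)Nc2cc(-c3ccccc3)nn2-c2ccccc2)cc1` carries a 4-carbamoylphenyl in the same place. In this assay compound 2 gives > 10000 nM, which is a limit of the assay and not a number. The step of an at least 12-fold higher number from compound 1 to compound 2 (1.10 log units; beyond the scatter) therefore rests on the limit of > 10000 nM in this assay, at which 1 of the 2 values shown sits, at its upper end, and compound 2 stands at the weak end of what has been measured, with only a limit to its name.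

Compound 3 `O=C(Nc1cc(-c2ccccc2)nn1-c1ccccc1)c1ccc(Cl)c(Cl)c1` is the next step: 3,4-dichlorophenyl in place of 4-carbamoylphenyl on a carbonyl carbon. Within the data shown here, only one measured step bears on it, an at least 12-fold higher number from compound 1 to compound 2 (1.10 log units; beyond the scatter), in which the carbamoyl arrived; here the carbamoyl leaves again and a 3,4-dichlorophenyl enters. The expectation is that removing the carbamoyl gives back most of what was lost in that step, so that in this assay a step of an at least 20-fold lower number from compound 2 to compound 3 (1.30 log units; beyond the scatter) is expected. The estimate for compound 3 is 500 nM, with a range from 100 nM to 3000 nM.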

Compound 3, inhibition constant: 160 nM
The estimate for compound 3 lay 3.1-fold (0.49 log units) above the measured number; the range from low to high includes it.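

In this assay the aryl group on the amide carbonyl can also lower the number relative to compound 1, whereas the earlier pair showed only a rise: the exchange for 3,4-dichlorophenyl gives a 4.9-fold lower number from compound 1 to compound 3 (0.69 log units; beyond the scatter). Compound 2 carries a limit and not a number, so the step of an at least 62-fold lower number from compound 2 to compound 3 (1.79 log units; beyond the scatter) fixes only a minimum size: the limit of > 10000 nM in this assay, at which 1 of the 3 values shown sits. Of the three aryl groups shown, 3,4-dichlorophenyl carries the lowest number, with both of its steps beyond the scatter, so a group without the carbamoyl and with two chlorines reads better here than either 4-methylphenyl or 4-carbamoylphenyl.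

The compounds shown leave open whether both chlorines of the 3,4-dichlorophenyl contribute to the step from compound 1 or whether a single chlorine would give the same number. They also leave open how a carboxylic acid or an amine would read in the place of the carbamoyl, and so whether the loss seen with compound 2 belongs to the carbamoyl alone.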